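A Phenyl Ring in Place of Cyclobutyl

The compounds below may be only part of what the source reports. "The series", "measured", "known", "first", "only" and "open" are said of these compounds alone.

Of the compounds shown here, three from this series have been tested in an in vitro ADME assay on microsomes from liver (Homo sapiens) for metabolic stability, tested at 5 uM; on this read-out lower numbers stand for a shorter-lived compound and higher numbers for a longer-lived compound. Compound 1 `COCN(c1ccc2c(c1)S(=O)(=O)N=C(c1c(O)c(-c3cccs3)nn(CCC(C)C)c1=O)N2)S(C)(=O)=O` gives 0.183 h in this assay. Compound 2 `CC(C)CCn1nc(C2CCCCC2)c(O)c(C2=NS(=O)(=O)c3cc(NS(C)(=O)=O)ccc3N2)c1=O` gives 0.117 h. Compound 3 `CS(=O)(=O)Nc1ccc2c(c1)S(=O)(=O)N=C(c1c(O)c(-c3cccs3)nn(CC3CCC3)c1=O)N2` is reported only as a limit, > 1 h, so its true half-life is not known as a number. This is the limit of > 1 h in this assay, at which 1 of the 3 values shown sits. Compound 3 therefore stands apart from compounds 1 and 2, whose values are plain numbers, and it is the longest-lived of the three as far as the data can tell.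

The next compound, compound 4 `CS(=O)(=O)Nc1ccc2c(c1)S(=O)(=O)N=C(c1c(O)c(-c3cccs3)nn(Cc3ccccc3)c1=O)N2`, has not yet been measured. It differs from compound 3 in one place: phenyl in place of cyclobutyl on a saturated chain carbon bound to an aromatic nitrogen. Among the compounds with values here, no pair of measured compounds shows this particular change, so no measured step can be quoted for it; the expectation rests on the shape of the change alone. In this assay the expected step is an at least 1.2-fold lower number from compound 3 to compound 4 (0.09 log units; that floor lies within the scatter), a modest loss that may still lie within the usual scatter. Compound 4 is accordingly estimated at 0.8 h, with a likely range from 0.3 h to 1.5 h. Compound 4 may also come back only as a limit in this assay.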

Compound 4, half-life: > 1 h
Compound 4: no number, only a limit; the forecaster's own chance of this, stated with the estimate: 40%; middle value at least 1.2-fold (0.09 log units) away from the limit.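

In this assay compound 4 gives > 1 h, which is a limit and not a number. Compound 3 is also reported only as a limit, so no step can be read between compound 3 and compound 4: the limit of > 1 h in this assay, at which 2 of the 4 values shown sit.

The compounds shown leave open whether phenyl in place of cyclobutyl changes the half-life at all, and in which direction.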